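The source may hold more compounds than are shown below. What is called first, only, known or untested is meant among the compounds shown, and "the series" means these compounds.

Compound 3 `C[C@@H](O[C@H]1CN2C(=O)C=C(C3=CCOCC3)CC2[C@@H]1c1ccc(F)cc1)c1cc(C(F)(F)F)cc(C(F)(F)F)c1` stands second highest of the three numbers measured in an assay on CHO cells for displacement of a labelled ligand from Substance-P receptor (Homo sapiens); a lower number here means a stronger inhibitor, a higher number a weaker inhibitor: compound 3 gives 0.18 nM, compound 2 `C[C@@H](O[C@H]1CN2C(=O)C=C(c3cc[n+]([O-])cc3)CC2[C@@H]1c1ccc(F)cc1)c1cc(C(F)(F)F)cc(C(F)(F)F)c1` gives 0.1 nM, and compound 1 `C[C@@H](O[C@H]1CN2C(=O)C=C(c3ccc(C#N)cc3)CC2[C@@H]1c1ccc(F)cc1)c1cc(C(F)(F)F)cc(C(F)(F)F)c1` gives 1.8 nM. The step from compound 3 to compound 4 `C[C@@H](O[C@H]1CN2C(=O)C=C(C3CCOCC3)CC2[C@@H]1c1ccc(F)cc1)c1cc(C(F)(F)F)cc(C(F)(F)F)c1` is a group of 6 heavy atoms (5 carbon, 1 oxygen; one six-membered non-aromatic ring with 1 hetero atom) in place of a group of 6 heavy atoms (5 carbon, 1 oxygen; one six-membered non-aromatic ring with 1 hetero atom), on a double-bonded ring carbon. Within the data shown here, no measured step changes this ring in the same way; the steps of a 10-fold lower number from compound 1 to compound 3 (1.00 log units; beyond the scatter) and an 18-fold lower number from compound 1 to compound 2 (1.26 log units; beyond the scatter) only show that this position tolerates varied six-membered rings, while a 1.8-fold higher number from compound 2 to compound 3 (0.26 log units; within the scatter) lies within the scatter. A step of a 2.2-fold higher number from compound 3 to compound 4 (0.35 log units; beyond the scatter) is therefore expected for compound 4, hardly beyond the scatter. Compound 4 is estimated at 0.4 nM, within 0.1 nM to 1.5 nM.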

Compound 4, half-maximal inhibitory concentration: 0.09 nM
Compound 4: middle estimate off by 4.4-fold (0.65 log units), on the high side; the measured number lies below the stated range.
By their numbers in this assay, from the lowest: compounds 4, 2 and 3 (each within the scatter of the next); then compound 1.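

In this assay, removing the double bond outside aromatic rings to give oxan-4-yl leaves the number within the scatter (a 2.0-fold lower number from compound 3 to compound 4 (0.30 log units; within the scatter)), so this position does not need that double bond. The same holds against the aromatic ring of compound 2 (a 1.1-fold lower number from compound 2 to compound 4 (0.05 log units; within the scatter)), while oxan-4-yl keeps the large gap to 4-cyanophenyl (a 20-fold lower number from compound 1 to compound 4 (1.30 log units; beyond the scatter)). Nothing given here explains these numbers. Still open, on these data alone, is how an amine such as piperidin-4-yl or an open alkyl chain would fare on this double-bonded ring carbon. Also open, as far as these compounds go, is whether unsubstituted phenyl would stand with 4-cyanophenyl or with the other rings.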